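The source may hold more compounds than are shown below. What is called first, only, known or untested is meant among the compounds shown, and "the series" means these compounds.

Measured in a functional assay on B16 cells (Mus musculus) for inhibition, with a stated time of 72 h; a higher number here means a weaker inhibitor, a lower number a stronger inhibitor:

- compound 1 `S=C1NCCCN1Cc1ccc(Cl)cc1`: 2400 nM
- compound 2 `COc1ccc(CN2CCCNC2=S)cc1`: 6100 nM

Compound 2, at 6100 nM, holds the higher of the two numbers, which makes it the weaker inhibitor of the pair. The next compound, compound 3 `CCc1ccc(CN2CCCNC2=S)cc1`, has not yet been measured. It carries ethyl in place of methoxy on an aromatic carbon. For the measured compounds named here, only one measured step bears on this change: a 2.5-fold higher number from compound 1 to compound 2 (0.41 log units; beyond the scatter), a modest move that came with methoxy in place of chloro on an aromatic carbon. Going by the values given here, no measured compound carries ethyl, so this is thin evidence. Losing the methoxy is expected to give only a small move toward a lower number, perhaps not beyond the scatter: a 1.6-fold lower number from compound 2 to compound 3 (0.21 log units; within the scatter) is the estimated step. For compound 3 the estimated value is 3800 nM, with a range from 1600 nM to 9000 nM.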

Compound 3, half-maximal inhibitory concentration: 1300 nM
Beside the measured number, compound 3's estimate is 2.9-fold (0.47 log units) above it; measured number below the stated range.
By their numbers in this assay, from the lowest: compounds 3 and 1 (each within the scatter of the next); then compound 2.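

In this assay the change from methoxy to ethyl gives a 4.7-fold lower number from compound 2 to compound 3 (0.67 log units; beyond the scatter) even though both groups have the same count of heavy atoms, so that count alone does not set the number at this aromatic carbon. Ethyl in place of chloro gives a 1.8-fold lower number from compound 1 to compound 3 (0.27 log units; within the scatter) and leaves those two groups indistinguishable in this assay, while methoxy is the one group of the three with a number clearly higher than the others. Nothing shown gives a reason for the gap between methoxy and the other two groups.

On these data alone, whether a longer chain such as propyl or butyl would hold the number at this carbon remains open. So does the effect of an amine or a carboxylic acid in the same place.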